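This account rests on a few compounds, and the source may have more. Where it says the series, first, only, none or still open, it means among the compounds named here.

Compound 1 `Nc1ccccc1NC(=O)c1ccc(CNC(=O)c2n[nH]cc2NC(=O)c2c(F)cccc2Cl)cc1`: 3630 nM
Compound 2 `Nc1ccccc1NC(=O)c1ccc(CNC(=O)c2n[nH]cc2NC(=O)c2ccccc2)cc1`: 6320 nM
Compound 3 `Nc1ccccc1NC(=O)c1ccc(CNC(=O)c2n[nH]cc2NC(=O)c2ccccc2F)cc1`: 9990 nM

These three values come from a functional assay on NCI-H460 cells (Homo sapiens) for inhibition, read by CCK-8 assay, with a stated time of 72 h; on this read-out lower numbers stand for stronger inhibition and higher numbers for weaker inhibition. Compound 3 stands clearly apart only from compound 1, with a 2.8-fold higher number from compound 1 to compound 3 (0.44 log units; beyond the scatter). Against compound 2 the gap is small, with a 1.6-fold higher number from compound 2 to compound 3 (0.20 log units; within the scatter).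

Compound 4 `Nc1ccccc1NC(=O)c1ccc(CNC(=O)c2n[nH]cc2NC(=O)c2c(F)cccc2F)cc1` keeps the shared core and turns 2-fluorophenyl into 2,6-difluorophenyl: fluoro in place of hydrogen on an aromatic carbon. The new fluoro sits ortho to a large group and meta to a fluoro group.

For the measured compounds named here, two measured steps bear on this change. The one of the same kind, fluoro in place of hydrogen, is a 1.6-fold higher number from compound 2 to compound 3 (0.20 log units; within the scatter), and it did not leave the scatter. The nearest structural relative is compound 1, which carries chloro where compound 4 gains fluoro, and there the step is a 2.8-fold higher number from compound 1 to compound 3 (0.44 log units; beyond the scatter). These hints are weak and point in different directions, so at most a small drop in this assay is expected, not clearly beyond the scatter. The estimated step is a 1.5-fold lower number from compound 3 to compound 4 (0.19 log units; within the scatter). Compound 4 is expected at 6500 nM, with an estimated range from 3000 nM to 13000 nM.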

Compound 4, half-maximal inhibitory concentration: 7790 nM
Beside the measured number, compound 4's estimate is 1.2-fold (0.08 log units) below it; the range from low to high includes it.
By their numbers in this assay, from the lowest: compounds 1, 2, 4 and 3 (each within the scatter of the next, the first and the last beyond it).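

In this assay a second fluoro on the 2-fluorophenyl group gives a step that stays within the usual scatter (a 1.3-fold lower number from compound 3 to compound 4 (0.11 log units; within the scatter)), and the 2,6-difluorophenyl group also cannot be told apart from plain phenyl (a 1.2-fold higher number from compound 2 to compound 4 (0.09 log units; within the scatter)). For the compounds shown here, exchanging fluoro for chloro is the only one of these new steps that goes beyond the scatter (a 2.1-fold higher number from compound 1 to compound 4 (0.33 log units; beyond the scatter)), although compound 1 itself stays within the scatter of the plain phenyl compound 2, so this chloro effect is modest and is seen only against the fluorinated partners. Nothing measured here explains these differences.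

On these data alone, it remains open whether a single chloro, without the fluoro of compound 1, would keep this gap. Also open, as far as these compounds go, is whether a larger change on this ring, such as a methoxy group or an amine, would move the number clearly beyond the scatter of plain phenyl.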